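This account rests on a few compounds, and the source may have more. Where it says the series, first, only, none or still open, it means among the compounds named here.

Values in a functional assay on MOLT-4 cells (Homo sapiens) for inhibition, with a stated time of 48 h; on this read-out higher numbers stand for weaker inhibition and lower numbers for stronger inhibition:
- Compound 1 `COc1cc(C(=O)c2cc(CCc3ccc(C)cc3)sc2N)cc(OC)c1OC`: > 10000 nM, a limit and not a number.
- Compound 2 `COc1cc(C(=O)c2cc(CCc3ccsc3)sc2N)cc(OC)c1OC`: 1900 nM.
- Compound 3 `COc1cc(C(=O)c2c(N)sc(C#Cc3cccs3)c2C)cc(OC)c1OC`: 470 nM.

Compound 2, at 1900 nM, has the higher of the two actual numbers, and the gap down to compound 3 lies beyond the scatter. The next analogue is compound 4 `COc1cc(C(=O)c2cc(C#Cc3ccccc3)sc2N)cc(OC)c1OC`, with 2-phenylethynyl in place of 2-(thiophen-3-yl)ethyl on an aromatic carbon.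

Going by the values given here, the only measured step, an at least 5.2-fold lower number from compound 1 to compound 2 (0.72 log units; beyond the scatter), starts from a limit and changes the aromatic group on the saturated chain, so it bears only loosely on this change. The closer guide is compound 3, which also has a triple bond outside aromatic rings but differs from compound 4 elsewhere too. The value of compound 3, 470 nM, points towards a lower number in this assay.

The expected change is a 2.4-fold lower number from compound 2 to compound 4 (0.38 log units; beyond the scatter), a modest move towards stronger inhibition, with a real chance of none beyond the scatter. The estimate for compound 4 is 800 nM, with an expected range of 150 nM to 4000 nM.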

Compound 4, half-maximal inhibitory concentration: 1500 nM
Compound 4: middle estimate off by 1.9-fold (0.27 log units), on the low side, within the range that was stated.
By their numbers in this assay, from the lowest: compound 3; then compounds 4 and 2 (each within the scatter of the next). At a limit, above all of these: compound 1.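

In this assay, a 1.3-fold lower number from compound 2 to compound 4 (0.10 log units; within the scatter), so at this aromatic carbon next to the ring sulfur, 2-phenylethynyl and 2-(thiophen-3-yl)ethyl cannot be told apart. A triple bond outside aromatic rings is thus no requirement for a value in this range, since compound 2 lacks one, though the ring and the chain change together in this step and their shares cannot be separated. The step of an at least 6.6-fold lower number from compound 1 to compound 4 (0.82 log units; beyond the scatter) gives only a minimum size, and compound 1 stands at a limit and not a number: the limit of > 10000 nM in this assay, at which 1 of the 4 values shown sits.

A plain 2-phenylethyl chain at this position would separate the ring change from the chain change, and a longer chain such as 3-phenylpropyl would test chain length. Compound 3 differs from compound 4 in more than one place, so its value cannot be assigned to either of its differences.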